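A few compounds are considered here, and "the series" means these few. Any claim that something is new, unique, unknown or untested is made for them only; others in the source may bear on it.

Compound 1 `FC(F)(F)c1ccc(CSc2nc(Nc3ccccc3Cl)c3ccccc3n2)cc1`: > 50000 nM
Compound 2 `CCOc1ccccc1Nc1nc(SCc2ccc(C(F)(F)F)cc2)nc2ccccc12`: > 50000 nM
Compound 3 `FC(F)(F)c1ccc(CSc2nc(Nc3cccc(Br)c3)c3ccccc3n2)cc1`: 25600 nM

Of the compounds shown here, three sharing one core have been tested in a functional assay on MCF7 cells (Homo sapiens) for cytotoxicity, read by MTT assay, with a stated time of 72 h; a lower number here means a stronger inhibitor, a higher number a weaker inhibitor. For compound 1 the result is a limit of the assay, > 50000 nM. For compound 2 the result is likewise a limit, > 50000 nM. Within the data shown here, compound 3 is the only one with a number, 25600 nM. The two other results both sit at the limit of > 50000 nM in this assay, at which 2 of the 3 values shown sit.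

Compound 4 `FC(F)(F)c1ccc(CSc2nc(Nc3ccc(Cl)cc3)c3ccccc3n2)cc1` differs from compound 3 in the group carried on the amine: 4-chlorophenyl in place of 3-bromophenyl on a nitrogen on an aromatic ring. Two measured steps change that same group. The step of an at least 1.9-fold lower number from compound 1 to compound 3 (0.29 log units; that floor lies within the scatter) and the step of an at least 1.9-fold lower number from compound 2 to compound 3 (0.29 log units; that floor lies within the scatter) both run from a limit to a number, so their full size stays unreadable, and their floors lie within the scatter. Both 2-substituted phenyl groups gave limits, and only the 3-bromophenyl gave a number. Among the measured compounds shown here, for the 4-chlorophenyl no step is measured.

Compound 4 is therefore expected to give a value near that of compound 3 in this assay, 32000 nM, with a likely range from 12000 nM to 80000 nM. The step of a 1.3-fold higher number from compound 3 to compound 4 (0.10 log units; within the scatter) is the change this estimate implies, and a result at the limit is also expected as a real possibility.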

Compound 4, half-maximal inhibitory concentration: 21500 nM
Beside the measured number, compound 4's estimate is 1.5-fold (0.17 log units) above it, within the range that was stated.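

In this assay, the 4-chlorophenyl group on the nitrogen gives a second measured number, and the step, a 1.2-fold lower number from compound 3 to compound 4 (0.08 log units; within the scatter), shows that it cannot be told apart from the 3-bromophenyl group of compound 3. Compound 4 also provides the first steps from the 2-ethoxyphenyl and 2-chlorophenyl groups that are printed as beyond the scatter, an at least 2.3-fold lower number from compound 2 to compound 4 (0.36 log units; beyond the scatter) and an at least 2.3-fold lower number from compound 1 to compound 4 (0.36 log units; beyond the scatter), although both are floors and their full size cannot be read. Among these four compounds, the two groups with a substituent at the 2-position are the ones that leave the result at a limit of the assay: the limit of > 50000 nM in this assay, at which 2 of the 4 values shown sit.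

Compound 4 differs from compound 3 in both the halogen and its place on the phenyl ring, and the compounds shown do not separate these two changes. They also leave open how the unsubstituted phenyl, 4-methoxyphenyl or pyridyl groups on this nitrogen would read in this assay, and whether any group there could give a much lower number.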